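Changing the aryl group on the ring nitrogen

The source may hold more compounds than are shown below. What is called first, only, known or untested is meant among the compounds shown, and "the series" means these compounds.

Measured compounds:
- compound 1, `Cc1ccc(Nc2cc(NC(=O)Nc3c(Cl)cccc3Cl)ncn2)cc1F`, 85.3%
- compound 2, `Cc1cc(F)cc(Nc2cc(NC(=O)Nc3c(Cl)cccc3Cl)ncn2)c1`, 49.1%

Both compounds were tested in a functional assay on HCC827 cells (Homo sapiens) for inhibition, read by MTT assay, with a stated time of 48 h, tested at 10 uM; on this read-out lower numbers stand for less inhibition and higher numbers for more inhibition at the one concentration tested (going by the name of the read-out). For the measured compounds named here, compound 2 stands at the lower of the two numbers: compound 1 gives 85.3%, and the only step measured so far, a number 36.2 percentage points lower from compound 1 to compound 2 (beyond the scatter), came from exchanging one aryl group for another on the nitrogen attached to the shared core. That single step shows the read-out can move a great deal when the aryl group on this nitrogen is altered.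

Compound 3, `COc1cc(Br)ccc1Nc1cc(NC(=O)Nc2c(Cl)cccc2Cl)ncn1`, has not yet been tested. It differs from compound 2 as follows: 4-bromo-2-methoxyphenyl in place of 3-fluoro-5-methylphenyl on a nitrogen on an aromatic ring. Going by the values given here, no measured step covers this particular exchange, so nothing directly tells which way the number will move. Among the compounds with values here, what the one measured step does say is that a change at this place can be large, so a wide range is appropriate.

On that basis compound 3 is estimated at 60%, within 30% to 88%, an expected step of a number 10.9 percentage points higher from compound 2 to compound 3 (beyond the scatter).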

Compound 3, a percentage reported as inhibition, at one concentration (the size of the read-out at that concentration, not a potency): 42.7%
For compound 3 the middle estimate is 17.3 percentage points above the measured one, within the range that was stated.
By their numbers in this assay, from the lowest: compounds 3 and 2 (each within the scatter of the next); then compound 1.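

In this assay, the new step is small (a number 6.4 percentage points lower from compound 2 to compound 3 (within the scatter)), so 3-fluoro-5-methylphenyl and 4-bromo-2-methoxyphenyl, two aryl groups that share no substituent, cannot be told apart at this position on the nitrogen. The exchange brings in an oxygen and a bromine, and with them one hydrogen-bond acceptor, yet it gives no number that can be separated from that of compound 2. The other new comparison is large (a number 42.6 percentage points lower from compound 1 to compound 3 (beyond the scatter)), so 3-fluoro-4-methylphenyl now stands apart from both other groups, and a second replacement for it has given a much lower number in this read-out.

With only three aryl groups shown, it remains open whether an amine or a carboxylic acid on the aryl ring, or a longer chain in place of that ring, would keep the high number of compound 1 or bring it down to the level of the other two. Nothing available gives a reason for the gap between compound 1 and the other two compounds.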